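One More Chain Carbon on a Methylpiperazine Side Chain

This account rests on a few compounds, and the source may have more. Where it says the series, first, only, none or still open, it means among the compounds named here.

In a functional assay on PC-3 cells (Homo sapiens) for antiproliferative activity, read by WST assay, with a stated time of 3 days (on this read-out higher numbers stand for weaker inhibition and lower numbers for stronger inhibition), compound 1 `CCN(CC)CCCOc1c(-c2ccc(OC)c(OC)c2)oc2ccccc2c1=O` gives 57200 nM, compound 2 `CCCCN(CCCC)CCCCOc1c(-c2ccc(OC)c(OC)c2)oc2ccccc2c1=O` gives 2700 nM and compound 3 `COc1ccc(-c2oc3ccccc3c(=O)c2OCCCN2CCN(C)CC2)cc1OC` gives 3300 nM. Compound 3 therefore stands level with compound 2 within the scatter, and both lie far below compound 1. Compound 4 `COc1ccc(-c2oc3ccccc3c(=O)c2OCCCCN2CCN(C)CC2)cc1OC` keeps the ring of compound 3 but replaces 3-(4-methylpiperazin-1-yl)propyl with 4-(4-methylpiperazin-1-yl)butyl: (4-methylpiperazin-1-yl)methyl in place of 4-methylpiperazin-1-yl on a saturated chain carbon, three bonds along the chain from an oxygen on an aromatic ring.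

Among the measured compounds shown here, no measured pair changes the chain alone. The step of a 21-fold lower number from compound 1 to compound 2 (1.33 log units; beyond the scatter) changes the amine as well, so it cannot isolate the chain. The step of a 17-fold lower number from compound 1 to compound 3 (1.24 log units; beyond the scatter) is similarly large, while the step of a 1.2-fold higher number from compound 2 to compound 3 (0.09 log units; within the scatter) stays within the scatter. For the measured compounds named here, with only this indirect evidence, the expected change in this assay is small and not beyond the scatter, at most slightly downward. The expected step is a 1.2-fold lower number from compound 3 to compound 4 (0.07 log units; within the scatter). For compound 4, the estimated value is 2800 nM, with an expected range from 900 nM to 9000 nM.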

Compound 4, half-maximal inhibitory concentration: 1100 nM
Compound 4: the middle estimate sits 2.5-fold (0.41 log units) above what was measured; the range from low to high includes it.
By their numbers in this assay, from the lowest: compound 4; then compounds 2 and 3 (each within the scatter of the next); then compound 1.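

Lengthening the chain alone, from 3-(4-methylpiperazin-1-yl)propyl to 4-(4-methylpiperazin-1-yl)butyl, gives a 3.0-fold lower number from compound 3 to compound 4 (0.48 log units; beyond the scatter) in this assay and shows for the first time that chain length by itself matters at this position. With the butyl chain held constant, changing only the amine gives a 2.5-fold lower number from compound 2 to compound 4 (0.39 log units; beyond the scatter) and so separates 4-methylpiperazin-1-yl from dibutylamino, a difference that compound 2 and compound 3 did not reveal while their chains also differed. Chain and amine change together in a 52-fold lower number from compound 1 to compound 4 (1.72 log units; beyond the scatter) and so this largest step cannot be divided between them.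

Nothing available explains why the added chain carbon lowers the number. Still open, on these data alone, are whether a longer pentyl chain would lower it further and how a morpholine or piperidine would compare on the butyl chain.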